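The compounds below may be only part of what the source reports. "The series", "measured", "known", "first", "only" and "open" are said of these compounds alone.

Compound 1 `Cc1ccc(-c2c[nH]nn2)cc1` is a small aryl triazole that, in an assay for inhibition of Indoleamine 2,3-dioxygenase 1 (Homo sapiens), with a stated time of 30 min (a higher number here means a weaker inhibitor, a lower number a stronger inhibitor), returns only the note "not active" (no number reported); there is no number to place it on. Its closest neighbour in the set, compound 2 `COc1ccc(-c2cnn[nH]2)cc1`, carries a methoxy group on the same kind of phenyl ring and gives in this assay a value of 6000000 nM, a number so high that it sits at the far weak end of what such a measurement can resolve. Compound 3 `Brc1ccc(-c2c[nH]nn2)cc1` differs from compound 1 by the change (bromo in place of methyl on an aromatic carbon). Among the compounds with values here, no measured pair in this set shows what such a swap does here, so the size of the step cannot be drawn from the data; with both measured compounds weak or inactive, nothing suggests a move beyond the scatter in either direction. Compound 3 is therefore expected to land near 5000000 nM, within a range of 1000000 nM to 30000000 nM.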

Compound 3, half-maximal inhibitory concentration: 1260000 nM
Compound 3: the middle estimate sits 4.0-fold (0.60 log units) above what was measured, within the range that was stated.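

Within the data shown here, compound 1 carries no number in this assay, so no step from it to compound 3 can be read. The compounds shown leave open what bromo in place of methyl does in this assay. No supporting measurement bears on this result.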